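The source may report more compounds than this note shows. Statements on the series, on what has been measured and on what is new or still open speak of the compounds shown alone.

Measured so far, in a functional assay on HL-60 cells (Homo sapiens) for antiproliferative activity, read by MTT assay, with a stated time of 24 h; a lower number here means a stronger inhibitor, a higher number a weaker inhibitor:

Compound 1 `CCCCc1oc2ccccc2c1C(=O)c1ccc(OCC(=O)NCc2ccccc2)cc1` — > 50000 nM
Compound 2 `CCCCc1oc2ccccc2c1C(=O)c1ccc(OCC(=O)N[C@@H](C)c2ccccc2)cc1` — > 50000 nM
Compound 3 `CCCCc1oc2ccccc2c1C(=O)c1cc(I)c(OCCCN2CCN(C)CC2)c(I)c1` — > 50000 nM

Each of these three values is a limit of this assay, not a number. Compound 1 reaches only the limit > 50000 nM. Compound 2 likewise stops at the limit > 50000 nM. Compound 3 too gives only the limit > 50000 nM. All three sit at the same boundary, as the limit of > 50000 nM in this assay, at which 3 of the 3 values shown sit, records.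

The change from compound 1 to compound 2 is methyl in place of hydrogen on a saturated chain carbon bound to an amide-type nitrogen and an aromatic carbon. Its step, a step that the two limits leave unreadable from compound 1 to compound 2, cannot be read, since both ends are limits. Compound 4 `CCCCc1oc2ccccc2c1C(=O)c1cc(I)c(OCCCN2CCN(CC)CC2)c(I)c1` has not yet been measured in this assay. It arises from compound 3 by methyl in place of hydrogen on a saturated chain carbon bound to an amine nitrogen in a ring. For the measured compounds named here, this is the same kind of change as the one from compound 1 to compound 2, not the same change: there the methyl enters on a saturated chain carbon bound to an amide-type nitrogen and an aromatic carbon, here on a saturated chain carbon bound to an amine nitrogen in a ring. The difference between the two cores is not broken down here. The same change thus occurs in two pairs among the compounds shown.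

Going by the values given here, because compound 3 itself reports only the limit > 50000 nM, and because the limit of > 50000 nM in this assay, at which 3 of the 3 values shown sit, shows every value so far at that boundary, the step that the limit leaves unreadable from compound 3 to compound 4 that this estimate means for compound 4 is expected to stay unreadable in the same way. Compound 4 is therefore estimated at 60000 nM, most likely again as a limit, within 20000 nM to 200000 nM.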

Compound 4, half-maximal inhibitory concentration: 28500 nM
The estimate for compound 4 lay 2.1-fold (0.32 log units) above the measured number; low and high end bracket the measured number.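

In this assay, putting methyl in place of hydrogen on a saturated chain carbon bound to an amine nitrogen in a ring, which turns 4-methylpiperazin-1-yl into 4-ethylpiperazin-1-yl, gives an at least 1.7-fold lower number from compound 3 to compound 4 (0.24 log units; that floor lies within the scatter); since only a floor is known and it lies within the scatter, this core shows no sure gain from the change, though a larger one is not ruled out. The same kind of change on the core of compound 1, the step to compound 2, cannot be read, since both ends are limits, so the data do not show whether the change carries from one core to the other. The comparison stays closed because almost every reading stops at one boundary: the limit of > 50000 nM in this assay, at which 3 of the 4 values shown sit.

The compounds shown leave open whether a longer chain, such as propyl, in place of the ethyl of the 4-ethylpiperazin-1-yl group would continue the step or reverse it. They also leave open whether a basic amine chain in place of the amide side chain of compound 1 would bring that core off its limit and make a direct comparison of the two cores possible.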